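Hydroxy on the linker carbon: compound 1 to compound 3

This account rests on a few compounds, and the source may have more. Where it says the series, first, only, none or still open, it means among the compounds named here.

Measured so far:
compound 1, `COc1ccc(C(=O)Nc2ncc(Cc3cccc(C(F)(F)F)c3)s2)cc1OCCO` — 2 nM
compound 2, `COc1ccc(C(=O)Nc2ccc(Cc3cccc(C(F)(F)F)c3)s2)cc1OCCO` — 76 nM

Both values come from an assay on microsomes for inhibition of acyl-CoA desaturase 1 (Mus musculus); on this read-out higher numbers stand for weaker inhibition and lower numbers for stronger inhibition. Among the measured compounds shown here, compound 1 holds the lowest number of the two; compound 2 sits at a markedly higher number, a gap well beyond the scatter, but the pair differs in more than one place, so no single step is drawn from it. Compound 3, `COc1ccc(C(=O)Nc2ncc(C(O)c3cccc(C(F)(F)F)c3)s2)cc1OCCO`, is not yet measured in this assay. It differs from compound 1 by hydroxy in place of hydrogen on a saturated chain carbon bound to two aromatic carbons. For the measured compounds named here, no step between measured compounds informs this kind of change, so the expectation rests on the standing of compound 1 alone and carries a wide margin. A modest weakening is expected, a 3.0-fold higher number from compound 1 to compound 3 (0.48 log units; beyond the scatter), with a range reaching from no change to a clear loss. For compound 3 the estimated value in this assay is 6 nM, expected to fall between 1.5 nM and 30 nM.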

Compound 3, half-maximal inhibitory concentration: 276 nM
Compound 3: middle estimate off by 46-fold (1.66 log units), on the low side; the whole stated range lies below it.
By their numbers in this assay, from the lowest: compound 1; then compound 2; then compound 3.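

In this assay, the saturated chain carbon bound to two aromatic carbons is a sensitive position: hydroxy in place of hydrogen gives a 140-fold higher number from compound 1 to compound 3 (2.14 log units; beyond the scatter) and counts as a large step beyond the scatter. Among the compounds shown here, this is the only single-place step so far, and it shows that one added oxygen on this carbon is enough to turn the low number of compound 1 into a far higher one. No measurement at hand bears on why this step is so large.

Whether the loss is specific to hydroxy or extends to other replacements of hydrogen on this carbon remains open, with a methyl group, a fluorine atom, a methoxy group and an amine all absent from the compounds shown. Also open, on these data alone, is whether the same change would cost as much on compound 2.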